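Swapping Acetyl for Methylsulfonyl on an Amine Nitrogen

The compounds below may be only part of what the source reports. "The series", "measured", "known", "first", "only" and "open" are said of these compounds alone.

In an ADME assay on liver (Rattus norvegicus) for metabolic stability, read by LC-MS, using S9 fraction, with a stated time of 30 min, tested at 5 uM, in the presence of a further agent that is not named here (a lower number here means slower removal, a higher number faster removal of the compound), compound 1 `CN(C)c1nonc1/C(=N/O)Nc1ccc(F)c(Br)c1` is reported only as a limit, > 36.6 mL/min/kg. Compound 2 `NCCNc1nonc1/C(=N/O)Nc1ccc(F)c(Br)c1` gives 18.3 mL/min/kg, and compound 3 `CC(=O)NCCNc1nonc1/C(=N/O)Nc1ccc(F)c(Br)c1` gives 15 mL/min/kg. These two numbers lie within the scatter of each other, so compound 3 stands level with compound 2.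

Putting (2-acetamidoethyl)amino in place of dimethylamino on an aromatic carbon gives an at least 2.4-fold lower number from compound 1 to compound 3 (0.38 log units; beyond the scatter), while (2-aminoethyl)amino in the same place gives an at least 2.0-fold lower number from compound 1 to compound 2 (0.30 log units; that floor lies within the scatter). Compound 4 `CS(=O)(=O)NCCNc1nonc1/C(=N/O)Nc1ccc(F)c(Br)c1` now carries methylsulfonyl in place of acetyl on an amine nitrogen.

The nearest guide is the earlier change on that nitrogen, acetyl in place of hydrogen, which gave a 1.2-fold lower number from compound 2 to compound 3 (0.09 log units; within the scatter). With so small a step as the precedent, no change beyond the scatter is expected in this assay. The expected change is no change at the digits printed from compound 3 to compound 4 (within the scatter). For compound 4 the estimated clearance is 15 mL/min/kg, with an expected range of 8 mL/min/kg to 28 mL/min/kg.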

Compound 4, clearance: 11.7 mL/min/kg
Beside the measured number, compound 4's estimate is 1.3-fold (0.11 log units) above it; the range from low to high includes it.
By their numbers in this assay, from the lowest: compounds 4, 3 and 2 (each within the scatter of the next). At a limit, above all of these: compound 1.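

In this assay, methylsulfonyl on the amine nitrogen sits level with acetyl: a 1.3-fold lower number from compound 3 to compound 4 (0.11 log units; within the scatter). Against the free amine the result is the same, a 1.6-fold lower number from compound 2 to compound 4 (0.19 log units; within the scatter), so compound 2, compound 3 and compound 4 cannot be told apart here, whichever of the three stands on that nitrogen. What compound 4 adds is a second capped chain that clears the scatter against dimethylamino, an at least 3.1-fold lower number from compound 1 to compound 4 (0.49 log units; beyond the scatter), although compound 1 is reported only as a limit, so that step is a floor: the limit of > 36.6 mL/min/kg in this assay, at which 1 of the 4 values shown sits.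

On these data alone, how far a larger group on this nitrogen, such as benzoyl or phenylsulfonyl, would stay level remains open. So does whether a longer chain or a carboxylic acid in place of the capped amine would keep the numbers in this range.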